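This account rests on a few compounds, and the source may have more. Where it says the series, first, only, none or still open, it means among the compounds named here.

Values in an ADME assay on MDCK cells (Canis lupus familiaris) for cytotoxicity, read by MTT assay, with a stated time of 48 h; on this read-out higher numbers stand for lower toxicity in this test and lower numbers for higher toxicity in this test

- compound 1 `Fc1ccc(-c2cn(CC3=C(Cl)c4ccc(-c5cccs5)nc4CC3)nn2)cc1` gives 100 ug/mL
- compound 2 `Fc1ccc(-c2cn(CC3=C(Cl)c4ccc(-c5cccs5)nc4CC3)nn2)c(F)c1` gives 188 ug/mL

Going by the values given here, compound 2 stands level with compound 1, as the only measured step shows: a 1.9-fold higher number from compound 1 to compound 2 (0.27 log units; within the scatter). Compound 3 `ClC1=C(Cn2cc(-c3ccsc3)nn2)CCc2nc(-c3cccs3)ccc21` has not yet been measured. It carries thiophen-3-yl in place of 2,4-difluorophenyl on an aromatic carbon of a five-membered aromatic ring with 3 nitrogen, and the counted change is thiophen-3-yl in place of 2,4-difluorophenyl on an aromatic carbon.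

Among the compounds with values here, the step from compound 1 to compound 2 is the only guide. It is a fluoro in place of hydrogen on an aromatic carbon and leaves the ring itself in place, so it bears on the new change only indirectly. Within the data shown here, no measured pair exchanges one aromatic ring for another. No shift beyond the scatter is therefore expected in this assay, although the uncertainty is wide and the lean is slightly downward. The expected step is a 1.4-fold lower number from compound 2 to compound 3 (0.16 log units; within the scatter). For compound 3 the estimated value is 130 ug/mL, with an expected range from 55 ug/mL to 300 ug/mL.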

Compound 3, half-maximal cytotoxic concentration: > 300 ug/mL
Compound 3 was reported as a limit; the forecaster's own chance of this, stated with the estimate: 15%; middle value at least 2.3-fold (0.36 log units) from the limit.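

In this assay the reading for compound 3 is a limit and not a number: the limit of > 300 ug/mL in this assay, at which 1 of the 3 values shown sits. The earlier pair only added fluoro to a ring that stayed in place, whereas this change replaces the whole ring on the aromatic carbon of the five-membered aromatic ring with 3 nitrogen, and thiophen-3-yl in place of 4-fluorophenyl gives an at least 3.0-fold higher number from compound 1 to compound 3 (0.47 log units; beyond the scatter). Against 2,4-difluorophenyl the same exchange gives an at least 1.5-fold higher number from compound 2 to compound 3 (0.20 log units; that floor lies within the scatter), so this position accepts a five-membered aromatic ring with sulfur without any sign of higher toxicity in this test, although the size of the shift from compound 2 remains only a floor.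

The compounds shown do not separate an effect of thiophen-3-yl itself from the loss of the fluorinated phenyl, and with a limit for compound 3 the true distance from either earlier compound stays unknown. An unsubstituted phenyl, a thiophen-2-yl, or a ring carrying an amine or a carboxylic acid at this position would show how far the trend holds beyond these three compounds.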